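Series notes: amide-side variation, rabbit plasma acetylhydrolase inhibition

The compounds below may be only part of what the source reports. "The series", "measured", "known", "first", "only" and "open" are said of these compounds alone.

Measured so far:
compound 1 `CCCCCCCCN(C)C(=O)Cn1cc(Cc2cnc(OCC)nc2)c(=O)nc1SCc1ccc(F)cc1`: 7%
compound 2 `CCCCCCCCN(C)C(=O)Cn1cc(Cc2cnc(OCc3ccccc3)nc2)c(=O)nc1SCc1ccc(F)cc1`: 8%
compound 3 `CCCCCCCCCCCCN(C)C(=O)Cn1cc(Cc2cnc(=O)n(CC(=O)OCC)c2)c(=O)nc1SCc1ccc(F)cc1`: 15%

All three were tested in a functional assay on a cell-free system (plasma, Oryctolagus cuniculus) for inhibition of platelet-activating factor acetylhydrolase (Homo sapiens), tested at 100 nM; a higher number here means more inhibition at the concentration tested (going by the name of the read-out), a lower number less inhibition. Compound 3 gives 15%; this number sits within the usual scatter of both compound 1 and compound 2, so no ordering among the three is supported. Among the compounds with values here, the only step measured, a number 1 percentage points higher from compound 1 to compound 2 (within the scatter), concerns a different part of the molecule and is itself within the scatter.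

Compound 4 `CCCCCCCCCCCCN(C)C(=O)Cn1cc(Cc2cnc(=O)n(CC(=O)N3CCNC(=O)C3)c2)c(=O)nc1SCc1ccc(F)cc1` differs from compound 3 by 3-oxopiperazin-1-yl in place of ethoxy on a carbonyl carbon. No measured step bears on this change, and the series has so far shown no movement beyond the scatter, so the expected step of no change at the digits printed from compound 3 to compound 4 (within the scatter) is none beyond the scatter. Compound 4 is estimated at 15%, between 4% and 30%.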

Compound 4, a percentage reported as inhibition, at one concentration (the size of the read-out at that concentration, not a potency): 49%
The estimate for compound 4 lay 34 percentage points below the measured number, outside the stated range (above it).
By their numbers in this assay, from the lowest: compounds 1, 2 and 3 (each within the scatter of the next); then compound 4.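

In this assay, within the data shown here, the carbonyl carbon is the first place where a change moves the number beyond the scatter: 3-oxopiperazin-1-yl in place of ethoxy gives a number 34 percentage points higher from compound 3 to compound 4 (beyond the scatter). The entering group adds a six-membered non-aromatic ring and a hydrogen-bond donor, neither of which ethoxy has. No measurement available here accounts for the step.

Going by these compounds, whether the step comes from the ring, its carbonyl or the amide hydrogen remains open. Morpholine or piperazine on the same carbonyl carbon would help separate these features.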